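This account rests on a few compounds, and the source may have more. Where it says the series, first, only, none or still open, it means among the compounds named here.

Measured in an ADME assay on Caco-2 cells (Homo sapiens) for permeability, read by LC-MS, in the apical to basolateral direction, with a stated time of 60 min, at pH 6.5; a lower number here means that the compound crosses the layer more slowly, a higher number that the compound crosses the layer faster:

Compound 1 `CC(C)(C)OC[C@@H](O)C(=O)N1[C@H](C(=O)NCc2cc(Cl)ccc2-n2cnnn2)C[C@@H]2C[C@@H]21`: 4.5 10^-6 cm/s
Compound 2 `CC(C)(C)[C@@H](O)C(=O)N1CSC(C)(C)[C@H]1C(=O)NCc1cc(Cl)ccc1-n1cnnn1`: 6.2 10^-6 cm/s
Compound 3 `O=C(NCc1cc(Cl)ccc1-n1cnnn1)[C@@H]1CCNN1C(=O)[C@H](O)c1ccccc1`: 5.3 10^-6 cm/s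

These three numbers sit within the usual scatter of one another, so compound 1 cannot be told apart from compound 2 or compound 3 in this test. Together they form one tight group, and compound 1 stands inside it.

The next compound to be tested is compound 4 `O=C(NCc1cc(Cl)ccc1-n1cnnn1)[C@@H]1C[C@@H]2C[C@@H]2N1C(=O)[C@H](O)Cc1ccccn1`. It keeps the core of compound 1 and changes one group: pyridin-2-yl in place of tert-butoxy on a saturated chain carbon, two bonds along the chain from a carbonyl carbon and an oxygen on a saturated carbon. In words, pyridin-2-yl takes the place of tert-butoxy on a saturated chain carbon, two bonds along the chain from a carbonyl carbon and an oxygen on a saturated carbon.

For the measured compounds named here, no pair of measured compounds differs in just one place, so the data offer no direct guide to this swap. Going by the values given here, the only guide in this assay is the narrow spread: compound 2 at 6.2 10^-6 cm/s and compound 3 at 5.3 10^-6 cm/s stay within the scatter of compound 1 at 4.5 10^-6 cm/s, although their structures differ in more than one place. On that basis, no change beyond the scatter is expected, and any drift could go either way, with a slight lean downward.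

The expected change is a 1.1-fold lower number from compound 1 to compound 4 (0.05 log units; within the scatter), which would stay within the scatter. Compound 4 is estimated at 4 10^-6 cm/s, with an expected range of 1.8 10^-6 cm/s to 8 10^-6 cm/s.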

Compound 4, apparent permeability: 1.2 10^-6 cm/s
The estimate for compound 4 lay 3.3-fold (0.52 log units) above the measured number; the measured number lies below the stated range.
By their numbers in this assay, from the lowest: compound 4; then compounds 1, 3 and 2 (each within the scatter of the next).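

In this assay, for the compounds shown here, the earlier compounds gave no single change to read, so nothing showed whether the group on this saturated chain carbon, two bonds along the chain from a carbonyl carbon and an oxygen on a saturated carbon, matters at all. Putting pyridin-2-yl in place of tert-butoxy now gives a 3.8-fold lower number from compound 1 to compound 4 (0.57 log units; beyond the scatter), a step beyond the usual scatter, so with the core of compound 1 kept, this position does affect how fast a compound crosses the cell layer. The step appears even though both groups count the same hydrogen-bond donors and acceptors and neither carries a net charge, so those counts do not separate them, and nothing measured here explains the drop.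

This single swap cannot show whether the step follows from the entering aromatic ring, its ring nitrogen, or the loss of the tert-butoxy group itself. Cyclohexyl in the same place would help separate ring from nitrogen, and pyridin-3-yl would test whether the placement of that nitrogen matters.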